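From trifluoromethyl to methyl on the phenyl ring

This account rests on a few compounds, and the source may have more. Where it says the series, first, only, none or still open, it means among the compounds named here.

Compound 2 `C=C1C[C@]23C[C@@]1(O)CC[C@H]2c1cc(Br)c(O)c(C)c1[C@@H]3Cn1cc(-c2ccc(C(F)(F)F)cc2)nn1` carries a 4-(trifluoromethyl)phenyl group on the shared core. Within the data shown here, in a functional assay on SW480 cells (Homo sapiens) for cytotoxicity, read by MTT assay, with a stated time of 4 days (a higher number here means a weaker inhibitor, a lower number a stronger inhibitor), compound 2 gives 15200 nM, the only number recorded here. Compound 1 `C=C1C[C@]23C[C@@]1(O)CC[C@H]2c1cc(Br)c(O)c(C)c1[C@@H]3Cn1cc(-c2ccc(F)cc2)nn1`, with fluoro in that place, gives in this assay a limit of the assay rather than a number, > 20000 nM. Among the measured compounds shown here, the step of an at least 1.3-fold lower number from compound 1 to compound 2 (0.11 log units; that floor lies within the scatter) is the sole measured comparison, and it stays within the scatter. Compound 3 `C=C1C[C@]23C[C@@]1(O)CC[C@H]2c1cc(Br)c(O)c(C)c1[C@@H]3Cn1cc(-c2ccc(C)cc2)nn1` differs from compound 2 by methyl in place of trifluoromethyl on an aromatic carbon. For the measured compounds named here, no measured step tests this change, and the one nearby step is small, so in this assay compound 3 is expected to show a 1.1-fold higher number from compound 2 to compound 3 (0.05 log units; within the scatter), nothing beyond the scatter. Compound 3 is therefore estimated at 17000 nM, between 7000 nM and 40000 nM.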

Compound 3, half-maximal inhibitory concentration: > 20000 nM
Compound 3 gave a limit, no number (the forecaster's own chance of this, stated with the estimate: 40%); middle value at least 1.1-fold (0.07 log units) away from the limit.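

In this assay the change to methyl gives an at least 1.3-fold higher number from compound 2 to compound 3 (0.11 log units; that floor lies within the scatter), so swapping these two groups at this position is not shown to matter. Compound 3 reads as a limit of the assay, not a number, and the step from compound 1 to compound 3 cannot be read. With fluoro, trifluoromethyl or methyl on this phenyl ring, the readings crowd at one end: the limit of > 20000 nM in this assay, at which 2 of the 3 values shown sit.

Going by these compounds, whether an amine or a carboxylic acid at this position would bring the number down stays open. On these data alone, how far compound 1 and compound 3 truly lie past the limit also stays unknown.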